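Methyl in place of bromo: compound 4 from compound 1

The source may hold more compounds than are shown below. What is called first, only, known or untested is meant among the compounds shown, and "the series" means these compounds.

The series shares one core and varies the aryl group on a saturated ring carbon. Compound 1 `CC(=O)N1N=C(c2ccc3ccccc3c2)OC1c1ccc(Br)cc1` carries 4-bromophenyl there; in a functional assay on B16-F10 cells (Mus musculus) for antiproliferative activity, read by MTT assay, with a stated time of 48 h (a higher number here means a weaker inhibitor, a lower number a stronger inhibitor), compound 1 gives 4.68 ug/mL. Compound 2 `CC(=O)N1N=C(c2ccc3ccccc3c2)OC1c1cccc(F)c1` carries 3-fluorophenyl, and in this assay compound 2 gives 1.61 ug/mL. Compound 3 `CC(=O)N1N=C(c2ccc3ccccc3c2)OC1c1ccccc1O` carries 2-hydroxyphenyl, and in this assay compound 3 gives 2.58 ug/mL. Compound 1 thus stands at the highest of the three numbers: a 2.9-fold lower number from compound 1 to compound 2 (0.46 log units; beyond the scatter), while a 1.8-fold lower number from compound 1 to compound 3 (0.26 log units; within the scatter) and a 1.6-fold higher number from compound 2 to compound 3 (0.20 log units; within the scatter).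

Compound 4 `CC(=O)N1N=C(c2ccc3ccccc3c2)OC1c1ccc(C)cc1` differs from compound 1 in one place: methyl in place of bromo on an aromatic carbon. For the measured compounds named here, no measured step exchanges one substituent for another on the same aromatic carbon of this aryl group; the two steps from compound 1 each replace the whole aryl group, and even then the larger of them is only modest and the smaller lies within the scatter. With the whole ring tolerating such replacement, a single swap of methyl for bromo is expected to move the number little, and no direction beyond the scatter can be read from the set. The expected step is therefore a 1.3-fold lower number from compound 1 to compound 4 (0.11 log units; within the scatter). Compound 4 is estimated to give 3.6 ug/mL in this assay, with an expected range from 1.8 ug/mL to 7.5 ug/mL.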

Compound 4, half-maximal inhibitory concentration: 3.85 ug/mL
Compound 4: middle estimate off by 1.1-fold (0.03 log units), on the low side; the range from low to high includes it.
By their numbers in this assay, from the lowest: compounds 2, 3, 4 and 1 (each within the scatter of the next, the first and the last beyond it).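

In this assay, for the compounds shown here, replacing bromo with methyl on an aromatic carbon para to a large group gives a 1.2-fold lower number from compound 1 to compound 4 (0.08 log units; within the scatter) and is the first step here that changes only a substituent while keeping the ring, so these two groups cannot be told apart at this position. Compound 4 shows a 1.5-fold higher number from compound 3 to compound 4 (0.17 log units; within the scatter) and so stays within the scatter of the 2-hydroxyphenyl compound, just as compound 1 does, while it shows a 2.4-fold higher number from compound 2 to compound 4 (0.38 log units; beyond the scatter) and so repeats the separation from the 3-fluorophenyl compound already seen with compound 1. Compound 2 is therefore set apart from both 4-substituted compounds, though compound 3 goes against any clean division because it lies within the scatter of compounds 1, 2 and 4 alike.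
No independent measurement bears on these numbers.

From the compounds shown here alone, whether this flat response at the para carbon holds for an amine, a carboxylic acid or a longer chain remains open. The compounds shown also do not separate the identity of fluoro from its place on the ring in compound 2, so it is unclear which of the two goes with the separation.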